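The compounds below may be only part of what the source reports. "The series", "measured", "known", "first", "only" and "open" are said of these compounds alone.

Compound 1 `CCC(=O)N1CC2CC(C1)N2` and compound 2 `CC(C)C(=O)N1CC2CC(C1)N2` share a core and differ only in the chain on the carbonyl. In an assay on SH-EP1 cells for agonist activity at Neuronal acetylcholine receptor; alpha4/beta2 (Homo sapiens), read by FLIPR and calcium flux (a lower number here means a smaller maximal response, a higher number a larger maximal response), compound 1 gives 98%, and compound 2 gives 86%. The one step measured so far, a number 12 percentage points lower from compound 1 to compound 2 (beyond the scatter), places compound 2 at the lower of the two numbers shown, with compound 1 as its only neighbour and a modest distance above it.

Compound 3 `O=C(C1CCC1)N1CC2CC(C1)N2` is not yet measured in this assay. It differs from compound 2 as follows: cyclobutyl in place of isopropyl on a carbonyl carbon. The incoming cyclobutyl group is a ring of four carbon atoms, one heavy atom more than the isopropyl group it replaces, on the same carbonyl carbon.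

Among the measured compounds shown here, only the step from compound 1 to compound 2 bears on this change, and it was a modest lowering as the chain on the carbonyl grew by one carbon. Growing it again, into a ring, is therefore expected to lower the maximal response by a similar or smaller amount, a number 6 percentage points lower from compound 2 to compound 3 (within the scatter), though a result within the scatter would not be surprising. For compound 3 the estimated value in this assay is 80%, expected to lie between 62% and 95%.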

Compound 3, largest response reached (Emax), in percent of the reference or control that the assay uses: 100%
Beside the measured number, compound 3's estimate is 20 percentage points below it, and the stated range ends below it.
By their numbers in this assay, from the lowest: compound 2; then compounds 1 and 3 (each within the scatter of the next).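

In this assay, the change from isopropyl to cyclobutyl on the carbonyl carbon gives a number 14 percentage points higher from compound 2 to compound 3 (beyond the scatter), so the earlier fall in maximal response does not continue when the group gains a carbon and closes into a ring. Set against the ethyl group, the cyclobutyl group gives a number 2 percentage points higher from compound 1 to compound 3 (within the scatter), which means compound 1 and compound 3 cannot be told apart here, while compound 2, with its isopropyl group, has the lowest number of the three and is the one compound that stands apart. Nothing available explains why the open branched group and the four-membered ring differ at this position.

The three compounds leave open whether the maximal response depends on the ring as such, since a cyclopropyl or cyclopentyl group on the same carbonyl carbon might stay with compound 3 or fall towards compound 2. They also leave open whether a tert-butyl group, more branched than isopropyl, would lower the response further, or whether compound 2 is simply an isolated dip in this short series.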